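Fluoro to propyl: working notes on a small series

The source may hold more compounds than are shown below. What is called first, only, known or untested is meant among the compounds shown, and "the series" means these compounds.

Among the measured compounds shown here, in a functional assay on HepG2 cells (Homo sapiens) for antiproliferative activity, read by CCK-8 assay, with a stated time of 72 h (a lower number here means a stronger inhibitor, a higher number a weaker inhibitor), compound 2 `Nc1ccccc1NC(=O)c1ccc(COc2ccc(F)cc2)cc1` gives 3840 nM, the only actual number so far. Compound 1 `CC(C)c1ccc(OCc2ccc(C(=O)Nc3ccccc3N)cc2)cc1` gives > 32000 nM, which is a limit of the assay and not a number.

Compound 3 `CCCc1ccc(OCc2ccc(C(=O)Nc3ccccc3N)cc2)cc1` differs from compound 2 at one place: propyl in place of fluoro on an aromatic carbon, para to a large group.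

For the measured compounds named here, one measured step bears on this change: an at least 8.3-fold lower number from compound 1 to compound 2 (0.92 log units; beyond the scatter), and its size rests on (the limit of > 32000 nM in this assay, at which 1 of the 2 values shown sits). Compound 3 carries propyl where compound 1 carries isopropyl, so a step of comparable size is expected in reverse, towards a higher number in this assay.

The estimated step is a 4.2-fold higher number from compound 2 to compound 3 (0.62 log units; beyond the scatter). For compound 3 the expected value is 16000 nM, with an estimated range of 6000 nM to 40000 nM.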

Compound 3, half-maximal inhibitory concentration: 4750 nM
Beside the measured number, compound 3's estimate is 3.4-fold (0.53 log units) above it; measured number below the stated range.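

In this assay, the change from 4-fluorophenyl to 4-propylphenyl gives a 1.2-fold higher number from compound 2 to compound 3 (0.09 log units; within the scatter), so this position accepts the propyl chain as readily as the fluoro group. The step from the first two compounds therefore cannot be read as a general penalty for replacing fluoro with an alkyl group, since the gap appears between the two alkyl groups, as an at least 6.7-fold lower number from compound 1 to compound 3 (0.82 log units; beyond the scatter) shows. Going by these compounds, the full size of that gap stays unknown, since compound 1 stands at a limit of the assay and not a number: the limit of > 32000 nM in this assay, at which 1 of the 3 values shown sits.

The compounds shown leave open whether a longer chain such as butyl, or a branched group such as tert-butyl, follows propyl or isopropyl here. They also leave open how an amine or a carboxylic acid would read at this position.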